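Three inactive esters and a chlorophenyl variant

This account rests on a few compounds, and the source may have more. Where it says the series, first, only, none or still open, it means among the compounds named here.

In a functional assay on QGY cells (Homo sapiens) for cytotoxicity, read by MTT assay (on this read-out higher numbers stand for weaker inhibition and lower numbers for stronger inhibition), compound 1 `CCOC(=O)C12C(=O)OCC=C1COC2c1ccccc1` gives > 1000000 nM, a limit of the assay. In this assay compound 2 `CCOC(=O)C12C(=O)OCC=C1COC2c1ccccc1F` gives > 1000000 nM, again a limit. In this assay compound 3 `CCOC(=O)C12C(=O)OCC=C1COC2c1ccc(F)cc1` gives > 1000000 nM, a limit as well.

Compound 3 therefore stands at the limit of > 1000000 nM in this assay, at which 3 of the 3 values shown sit, the same limit as the other two. The steps a step that the two limits leave unreadable from compound 1 to compound 2, a step that the two limits leave unreadable from compound 1 to compound 3 and a step that the two limits leave unreadable from compound 2 to compound 3 are all unreadable, so no aromatic substituent change has yet shown any readable effect. Compound 4 `CCOC(=O)C12C(=O)OCC=C1COC2c1cccc(Cl)c1` differs from compound 3 by 3-chlorophenyl in place of 4-fluorophenyl on a saturated ring carbon. With no readable step to build on, compound 4 is expected to sit at the same limit, an estimated step that the limit leaves unreadable from compound 3 to compound 4. Compound 4 is thus estimated at 2000000 nM, within 300000 nM to 10000000 nM.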

Compound 4, half-maximal inhibitory concentration: > 1000000 nM
Compound 4 was reported as a limit; the forecaster's own chance of this, stated with the estimate: 85%; the middle value lies beyond the limit too.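

Compound 4 sits at the same limit as compound 1, compound 2 and compound 3 in this assay, so none of the steps among them can be read: the limit of > 1000000 nM in this assay, at which 4 of the 4 values shown sit.

As far as these compounds go, whether any of these aromatic substituents changes the cytotoxicity of the shared core remains open.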